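Chloro to fluoro swap on a diethylamino analogue

A few compounds are considered here, and "the series" means these few. Any claim that something is new, unique, unknown or untested is made for them only; others in the source may bear on it.

Compound 1 `CC(C)(C)Nc1c(C#N)c(F)c2c(N)nc(N)nc2c1Cl` and compound 2 `CC(C)(C)Nc1c(C#N)c(F)c2c(N)nc(N)nc2c1F` differ by fluoro in place of chloro on an aromatic carbon. In a functional assay on HepG2 cells (Homo sapiens) for cytotoxicity, read by MTT assay (on this read-out lower numbers stand for stronger inhibition and higher numbers for weaker inhibition), compound 1 gives 5.4 ug/mL, and compound 2 gives 16.2 ug/mL, so that this change produces a 3.0-fold higher number from compound 1 to compound 2 (0.48 log units; beyond the scatter). Compound 3 `CCN(CC)c1c(C#N)c(F)c2c(N)nc(N)nc2c1Cl` has the same atoms as compound 1 joined differently, the difference being (diethylamino in place of (tert-butyl)amino on an aromatic carbon). In this assay compound 3 gives 2 ug/mL, the lowest number among the three measured compounds, and the step is a 2.7-fold lower number from compound 1 to compound 3 (0.43 log units; beyond the scatter). Compound 4 `CCN(CC)c1c(C#N)c(F)c2c(N)nc(N)nc2c1F` has not yet been measured. It differs from compound 3 by fluoro in place of chloro on an aromatic carbon, the same kind of change as that from compound 1 to compound 2 but not the same: in compound 1 the carbon is ortho to a (tert-butyl)amino group, in compound 3 it is ortho to a diethylamino group, while the rest of the place is described in the same words. Among the measured compounds shown here, no second measured pair shows this change, so the expectation rests on one pair only. For the measured compounds named here, for compound 4 in this assay the expected step is a 3.0-fold higher number from compound 3 to compound 4 (0.48 log units; beyond the scatter), set beside the earlier step because a 3.0-fold higher number from compound 1 to compound 2 (0.48 log units; beyond the scatter) is the only measured instance of the change. Compound 4 is estimated at 6 ug/mL, with a range expected from 3 ug/mL to 12 ug/mL.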

Compound 4, half-maximal inhibitory concentration: 1.3 ug/mL
Beside the measured number, compound 4's estimate is 4.6-fold (0.66 log units) above it, and the stated range ends above it.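

In this assay the fluoro-for-chloro swap does not carry from the (tert-butyl)amino core to the diethylamino core: with the diethylamino group the step is a 1.5-fold lower number from compound 3 to compound 4 (0.19 log units; within the scatter) and so separates the two halogens no more than repeat measurements would, unlike the step with the (tert-butyl)amino group: the same change on two cores in this assay, a 3.0-fold higher number (0.48 log units; beyond the scatter) from compound 1 to compound 2 and a 1.5-fold lower number (0.19 log units; within the scatter) from compound 3 to compound 4, 4.6-fold (0.66 log units) apart, beyond the scatter of two such steps
Read the other way, diethylamino in place of (tert-butyl)amino gives a lower number with either halogen, but the step with fluoro, a 12-fold lower number from compound 2 to compound 4 (1.10 log units; beyond the scatter) in this assay and large, is not the size of the step with chloro: the same change on two cores in this assay, a 2.7-fold lower number (0.43 log units; beyond the scatter) from compound 1 to compound 3 and a 12-fold lower number (1.10 log units; beyond the scatter) from compound 2 to compound 4, 4.6-fold (0.66 log units) apart, beyond the scatter of two such steps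
Both comparisons rest on the same four compounds, one pair for each step on each core, so they show that the size of each change depends on the group at the other place in this small set, but they do not show why, nor how far this holds beyond these compounds.

The compounds shown leave open whether the halogen swap would behave as it does with compound 3 and compound 4 on other amines, such as dimethylamino, pyrrolidinyl or morpholinyl. They also leave open how bromo or a hydrogen would compare with chloro and fluoro on these two cores.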